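Compound 3: trifluoromethyl in place of hydrogen

A few compounds are considered here, and "the series" means these few. Any claim that something is new, unique, unknown or untested is made for them only; others in the source may bear on it.

Values so far in a toxicity assay on BJ cells (Homo sapiens) for cytotoxicity, read by MTT assay, with a stated time of 24 h (a lower number here means a stronger inhibitor, a higher number a weaker inhibitor), are these two limits of the assay
- compound 1 `CCOC(=O)N1CCC(=NNC(=O)c2ccc(Cl)cc2)CC1` gives > 400000 nM as a limit
- compound 2 `O=C(NN=C1CC(c2ccccc2)NC(c2ccccc2)C1)c1ccccc1` gives > 400000 nM as a limit

Compound 2 stands at > 400000 nM in this assay and this entry is a limit of the assay, not a number. The series offers only the limit of > 400000 nM in this assay, at which 2 of the 2 values shown sit, and no measured number against which to rank compound 2.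

Compound 3 `O=C(NN=C1CC(c2ccccc2)NC(c2ccccc2)C1)c1ccc(C(F)(F)F)cc1` is the next compound to be tested. The change trifluoromethyl in place of hydrogen on an aromatic carbon puts trifluoromethyl in place of hydrogen on an aromatic carbon, para to a large group, and so turns phenyl to 4-(trifluoromethyl)phenyl.

Among the compounds with values here, no two measured compounds differ in one place, and no measured step bears on this change. No shift beyond the scatter is expected in this assay and any real shift is expected toward a stronger inhibitor. This expectation rests on compound 2 and its limit > 400000 nM alone. The expected change is an at least 1.0-fold lower number from compound 2 to compound 3 (0.02 log units; that floor lies within the scatter) and no more. For compound 3 the estimated value is 380000 nM with an expected range from 150000 nM to 600000 nM and another limit is the likeliest report.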

Compound 3, half-maximal inhibitory concentration: > 400000 nM
Compound 3: only a limit was reported (the forecaster's own chance of this, stated with the estimate: 65%); middle value at least 1.0-fold (0.02 log units) away from the limit.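

Compound 2 and compound 3 both report limits in this assay, so the step between them cannot be read: the limit of > 400000 nM in this assay, at which 3 of the 3 values shown sit.

The compounds shown leave open whether any member of this series reaches a numerical half-maximal inhibitory concentration in this assay, and whether trifluoromethyl in place of hydrogen changes that value.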